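The compounds below may be only part of what the source reports. "The series", "measured", "known", "first", "only" and "open" are said of these compounds alone.

Of the compounds shown here, two sharing one core have been measured in an assay on mitochondria from L6 cells (Rattus norvegicus) for activation, with a stated time of 90 min; on this read-out lower numbers stand for an effect already at smaller amounts and higher numbers for an effect only at larger amounts of compound. Compound 1 `Oc1nc2nonc2nc1Nc1ccccc1F` gives 12500 nM. Compound 2 `CCCCc1ccc(Nc2nc3nonc3nc2O)c(F)c1`, which carries butyl in place of hydrogen on an aromatic carbon, gives 1100 nM. Among the compounds with values here, the only measured step, an 11-fold lower number from compound 1 to compound 2 (1.06 log units; beyond the scatter), is a large one. Compound 2 therefore holds the lowest of the two numbers, and its nearest neighbour, compound 1, sits markedly higher.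

Compound 3 `CCCCCc1ccc(Nc2nc3nonc3nc2O)c(F)c1` has not yet been measured. It differs from compound 2 by methyl in place of hydrogen on a saturated chain carbon, four bonds along the chain from an aromatic carbon; read one bond further out, the same difference is propyl to butyl, so the chain simply grows longer. Within the data shown here, the measured step shows what the whole butyl group does when it enters where hydrogen stood; it does not show what one added methyl at the far end of that chain does, and no other step speaks to this. The expected step is a 1.2-fold lower number from compound 2 to compound 3 (0.09 log units; within the scatter), small and most likely within the scatter, with no clear direction. Compound 3 is estimated at 900 nM, with a range from 300 nM to 2700 nM.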

Compound 3, half-maximal effective concentration: 1500 nM
Estimate against measurement, compound 3: 1.7-fold (0.22 log units) below; the range from low to high includes it.
By their numbers in this assay, from the lowest: compounds 2 and 3 (each within the scatter of the next); then compound 1.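

In this assay, extending the butyl group to pentyl gives a 1.4-fold higher number from compound 2 to compound 3 (0.13 log units; within the scatter), so adding a methyl four bonds along the chain from an aromatic carbon produces no change that can be told apart from the usual scatter. Compared with the parent that has hydrogen on this aromatic carbon, pentyl gives an 8.3-fold lower number from compound 1 to compound 3 (0.92 log units; beyond the scatter), which shows that the lower number seen with butyl is not confined to that single chain length. No separate measurement is available to explain why these two chains read alike.

With only hydrogen, butyl and pentyl shown at this aromatic carbon, it remains open how short the chain can be, for example methyl or ethyl, before the number returns towards that of compound 1, and whether a longer chain such as hexyl or octyl would still read like compound 2 and compound 3. From the compounds shown here alone, it is also open whether the straight chain itself matters, which a branched group such as tert-butyl or a ring such as cyclohexyl could help to show.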